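Adding the same amide chain to a second core

A few compounds are considered here, and "the series" means these few. Any claim that something is new, unique, unknown or untested is made for them only; others in the source may bear on it.

Compound 1 `CC(C)C[C@H](N)c1cc(C(F)(F)F)ccc1N1CCN(C(=O)[C@H]2CSC[C@@H]2c2ccc(Cl)cc2)CC1` is the starting point of this set. In an assay on HEK293 cells for displacement of a labelled ligand from Melanocortin receptor 4 (Homo sapiens) (on this read-out higher numbers stand for weaker inhibition and lower numbers for stronger inhibition), compound 1 gives 280 nM. Compound 3 `CC(C)C[C@H](NC(=O)CCN(C)C)c1cc(C(F)(F)F)ccc1N1CCN(C(=O)[C@H]2CSC[C@@H]2c2ccc(Cl)cc2)CC1` differs from it in one place: (2-(dimethylamino)ethyl)carbonyl in place of hydrogen on an amine nitrogen. That single change brings a 2.2-fold lower number from compound 1 to compound 3 (0.33 log units; beyond the scatter), and in this assay compound 3 gives 130 nM.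

Compound 2 `CC(C)C[C@H](N)c1cc(C(F)(F)F)ccc1N1CCN(C(=O)[C@H]2C[S+]([O-])C[C@@H]2c2ccc(Cl)cc2)CC1` carries a different core; the difference between the two cores is not broken down here. In this assay compound 2 gives 120 nM.

Compound 4 `CC(C)C[C@H](NC(=O)CCN(C)C)c1cc(C(F)(F)F)ccc1N1CCN(C(=O)[C@H]2C[S+]([O-])C[C@@H]2c2ccc(Cl)cc2)CC1` has not yet been measured. It stands to compound 2 as compound 3 stands to compound 1: (2-(dimethylamino)ethyl)carbonyl in place of hydrogen on an amine nitrogen. The change sits on the same kind of place in both pairs, so it counts as the same change made on another core. Among the compounds with values here, the only guide to its effect is the measured pair, and on that basis the expected step is a 2.0-fold lower number from compound 2 to compound 4 (0.30 log units; within the scatter), because compound 1 to compound 3 gave a 2.2-fold lower number from compound 1 to compound 3 (0.33 log units; beyond the scatter). With compound 2 at its measured value, the estimate for compound 4 in this assay is therefore 60 nM, expected to lie between 25 nM and 150 nM.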

Compound 4, inhibition constant: 230 nM
Compound 4: the middle estimate sits 3.8-fold (0.58 log units) below what was measured; the whole stated range lies below it.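

On the core of compound 2, the (2-(dimethylamino)ethyl)carbonyl group on the amine nitrogen gives a 1.9-fold higher number from compound 2 to compound 4 (0.28 log units; within the scatter) and so leaves no clear difference in this assay. Set beside the result on the core of compound 1, the change does not carry over as a fixed step from one core to the other: the same change on two cores in this assay, a 2.2-fold lower number (0.33 log units; beyond the scatter) from compound 1 to compound 3 and a 1.9-fold higher number (0.28 log units; within the scatter) from compound 2 to compound 4, 4.1-fold (0.62 log units) apart, beyond the scatter of two such steps

This shows that, for these two pairs, the step measured on one core was a poor guide to the step on the other, but it rests on a single pair per core and does not show what lies behind the difference between them.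

The compounds shown leave open whether other groups on the same nitrogen, such as a plain acetyl group, a longer chain ending in the same dimethylamino group, or a chain ending in a carboxylic acid, would also behave differently on the two cores. They also leave open whether the gap between the two steps would hold up on repeated measurement or on a third core.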